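Moving the Methyl Within the Sulfamoyl Group of Compound 3

The source may report more compounds than this note shows. Statements on the series, on what has been measured and on what is new or still open speak of the compounds shown alone.

Compound 3, `CCN1CCCC1CNC(=O)c1cc(NS(=O)(=O)NC)c(Cl)cc1OC`, carries a chloro group on its core. In a functional assay on the whole organism for inhibition, with Canis familiaris (Canis lupus familiaris) as the target (a lower number here means that less compound is needed, a higher number that more compound is needed for the effect), compound 3 gives > 1 mg/kg, which is a limit of the assay and not a number. Compound 1, `CCN1CCCC1CNC(=O)c1cc(NS(=O)(=O)NC)ccc1OC`, is the same core without that chloro group, and in this assay compound 1 gives > 1 mg/kg, again a limit. Compound 2, `CCN1CCCC1CNC(=O)c1cc(NS(=O)(=O)NC)c(C)cc1OC`, has a methyl group in place of the chloro group, and in this assay compound 2 gives > 1 mg/kg, also a limit. All three values stand at one limit, as the limit of > 1 mg/kg in this assay, at which 3 of the 3 values shown sit, shows, so the three steps a step that the two limits leave unreadable from compound 1 to compound 2, a step that the two limits leave unreadable from compound 1 to compound 3 and a step that the two limits leave unreadable from compound 2 to compound 3 can be read neither in size nor in direction.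

Compound 4, `CCN1CCCC1CNC(=O)c1cc(N(C)S(N)(=O)=O)c(Cl)cc1OC`, has not yet been measured. Its change from compound 3 is methyl(sulfamoyl)amino in place of (methylsulfamoyl)amino on an aromatic carbon: the same atoms, joined differently, so the methyl moves from one nitrogen to the other. Among the compounds with values here, none of the measured steps touches this part of the molecule, and all measured values are limits, so no direction can be drawn from them. The step that the limit leaves unreadable from compound 3 to compound 4 is therefore estimated as small. For compound 4 in this assay the expected value is 3 mg/kg, estimated to fall between 0.8 mg/kg and 15 mg/kg.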

Compound 4, dose for half-maximal effect: 1 mg/kg
Compound 4: the middle estimate sits 3.0-fold (0.48 log units) above what was measured; the range from low to high includes it.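

In this assay, within the data shown here, compound 4 gives 1 mg/kg, the only real number among the four values shown, so this swap of methyl(sulfamoyl)amino for (methylsulfamoyl)amino is the one change here that yields a value that can be read as a number. Compound 3 gives > 1 mg/kg, which is a limit and not a number. Moving the methyl from the outer nitrogen to the nitrogen on the aromatic carbon therefore gives a number no higher from compound 3 to compound 4 (the limit leaves the size open), a direction that the earlier steps, none of which can be read, could not offer, though it may still mean no change at all, and its size stays hidden behind the shared limit: the limit of > 1 mg/kg in this assay, at which 3 of the 4 values shown sit.

The compounds shown leave open whether the same methyl move would give a similar value on the core of compound 1 or compound 2, where the chloro group is absent or replaced by methyl. They also leave open how the value would respond to a longer chain such as ethyl on that same nitrogen, or to a second methyl on the outer nitrogen.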